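Replacing thiophen-3-yl with 3-fluorophenyl on the shared core

The compounds below may be only part of what the source reports. "The series", "measured", "known", "first", "only" and "open" are said of these compounds alone.

Of the compounds shown here, two on a shared core have been measured so far. In a functional assay on THP-1 cells (Homo sapiens) for inhibition, read by ELISA, with stated times of 1 h and 18 h (on this read-out lower numbers stand for stronger inhibition and higher numbers for weaker inhibition), compound 1 (`NC(=O)[C@@H]1[C@H](Nc2nc(Nc3ccc(C(=O)N4CCCC4)cc3)ncc2-c2cccnc2)[C@H]2C=C[C@@H]1C2`) reads 230 nM as its half-maximal inhibitory concentration, and compound 2 (`NC(=O)[C@@H]1[C@H](Nc2nc(Nc3cccc(C(=O)N4CCCC4)c3)ncc2-c2ccsc2)[C@H]2C=C[C@@H]1C2`) reads 110 nM on the same scale. Compound 2 therefore holds the lower of the two numbers, and the gap between them lies beyond the usual scatter. The two compounds differ in more than one place, so that gap does not isolate any single change.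

Compound 3 (`NC(=O)[C@@H]1[C@H](Nc2nc(Nc3cccc(C(=O)N4CCCC4)c3)ncc2-c2cccc(F)c2)[C@H]2C=C[C@@H]1C2`) departs from compound 2 in one place, with 3-fluorophenyl in place of thiophen-3-yl on an aromatic carbon. For the measured compounds named here, no measured pair shows this replacement, so the only anchor for the expectation is compound 2 (110 nM). In this assay a small move towards weaker inhibition is expected, and the expected step (a 1.4-fold higher number from compound 2 to compound 3 (0.13 log units; within the scatter)) stays within the scatter. Compound 3 is estimated at 150 nM in this read-out, with an expected range from 60 nM to 400 nM overall.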

Compound 3, half-maximal inhibitory concentration: 870 nM
Estimate against measurement, compound 3: 5.8-fold (0.76 log units) below, and the stated range ends below it.
By their numbers in this assay, from the lowest: compound 2; then compound 1; then compound 3.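

In this assay, for the compounds shown here, the aromatic carbon ortho to a large group and para to a large group proved sensitive to the group it carries: putting 3-fluorophenyl in place of thiophen-3-yl gave a 7.9-fold higher number from compound 2 to compound 3 (0.90 log units; beyond the scatter) and so a clear loss of inhibition, the first change on the shared core that can be read in one place. The step is modest in the scale of the read-out, yet it shows that this position does not accept every aromatic ring equally. The change replaces a five-membered aromatic ring with 1 hetero atom by a six-membered aromatic ring of carbon only and also brings in fluorine, and nothing available here explains the loss or separates these features.

In this assay the compounds shown leave open whether a plain phenyl ring, without the fluorine, or a thiophen-2-yl group would read closer to compound 2 or to compound 3. Compound 1 carries pyridin-3-yl at this position but differs from compound 2 in more than one place, so what that ring contributes here stays unresolved as well.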